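Putting a Bulkier Amine Back on the Core

This account rests on a few compounds, and the source may have more. Where it says the series, first, only, none or still open, it means among the compounds named here.

Compound 1 `N#Cc1ccc(CNc2c(NC3CCCC3)c(=O)c2=O)cc1`, compound 2 `CCC(C)(C)/N=c1\c(O)c(O)\c1=N/Cc1ccc(C)c(C)c1` and compound 3 `N#Cc1ccc(CNc2c(N)c(=O)c2=O)cc1` share the same small core. In a functional assay for inhibition, with Rattus norvegicus as the target (a higher number here means a weaker inhibitor, a lower number a stronger inhibitor), compound 1 gives 9400 nM. Compound 2 reaches only the limit of the assay, > 30000 nM. Compound 3 also reaches only the limit of the assay, > 30000 nM. Compound 3 therefore stands at the weak edge of what this assay can report, a place it shares with compound 2 (the limit of > 30000 nM in this assay, at which 2 of the 3 values shown sit).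

Compound 4 `CN(c1c(NCc2ccc(C#N)cc2)c(=O)c1=O)C(C)(C)C` differs from compound 3 by methyl(tert-butyl)amino in place of amino on an aromatic carbon. Among the compounds with values here, the one measured step that speaks to this change runs the other way: an at least 3.1-fold higher number from compound 1 to compound 3 (0.50 log units; beyond the scatter). Taking the cyclopentyl off that nitrogen weakened inhibition, so putting a larger substituent back, here methyl(tert-butyl)amino with no hydrogen-bond donor left on it, is expected to pull the number down again. The step from compound 3 to compound 4 is estimated as an at least 2.0-fold lower number from compound 3 to compound 4 (0.30 log units; that floor lies within the scatter). For compound 4 the expected value in this assay is 15000 nM, with a plausible range from 4000 nM to 60000 nM.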

Compound 4, half-maximal inhibitory concentration: 18300 nM
Estimate against measurement, compound 4: 1.2-fold (0.09 log units) below, and the stated range covers the measured number.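

With methyl(tert-butyl)amino on this aromatic carbon, compound 4 gives a measured number in this assay, and the group is counted with 0 hydrogen-bond donors, so a donor on this nitrogen is not required for a reading inside the assay's range. The gain over the bare amino group appears as an at least 1.6-fold lower number from compound 3 to compound 4 (0.21 log units; that floor lies within the scatter), which is only a floor, and not a clear gain, since the value of compound 3 is a limit: the limit of > 30000 nM in this assay, at which 2 of the 4 values shown sit. Against the cyclopentylamino group the change is a 1.9-fold higher number from compound 1 to compound 4 (0.29 log units; within the scatter), so these two larger groups cannot be told apart here.

Still open, going by these compounds, is whether the methyl or the tert-butyl carries this result, which tert-butylamino alone would help to separate. On these data alone, it is also open whether a carboxylic acid or a longer chain at this place would move the number beyond the scatter.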